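The source may report more compounds than this note shows. Statements on the series, on what has been measured and on what is new or still open speak of the compounds shown alone.

Series notes, values in a functional assay on K562 cells (Homo sapiens) for inhibition, read by trypan blue exclusion, with a stated time of 72 h; a higher number here means a weaker inhibitor, a lower number a stronger inhibitor:

- compound 1 `Cn1c(=O)c(S(=O)(=O)c2ccc(F)cc2)cc2cnc(Nc3ccc4cc[nH]c4c3)nc21` gives 10000 nM
- compound 2 `Cn1c(=O)c(S(=O)(=O)c2ccccc2)cc2cnc(Nc3ccc4cc[nH]c4c3)nc21` gives 10000 nM
- compound 3 `Cn1c(=O)c(S(=O)(=O)c2ccc(F)cc2F)cc2cnc(Nc3ccc4cc[nH]c4c3)nc21` gives 5000 nM

Compound 1 stands level with compound 2 at the digits shown, and compound 3 lies within the scatter of both, so these three are not separated in this assay.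

The open question is compound 4 `Cn1c(=O)c(S(=O)(=O)c2ccc(F)cc2)cc2cnc(Nc3cccc4[nH]ccc34)nc21`, which has the same atoms as compound 1, joined differently: 1H-indol-4-yl in place of 1H-indol-6-yl on a nitrogen on an aromatic ring. In words, 1H-indol-4-yl stands in place of 1H-indol-6-yl on a nitrogen on an aromatic ring.

The measured steps are no change at the digits printed from compound 1 to compound 2 (within the scatter), a 2.0-fold lower number from compound 1 to compound 3 (0.30 log units; within the scatter) and a 2.0-fold lower number from compound 2 to compound 3 (0.30 log units; within the scatter). All three lie within the scatter, and all three concern fluoro on the aromatic group on the sulfonyl sulfur. Among the measured compounds shown here, none of them touches the indolyl attachment, so no measured step bears directly on this change. For the measured compounds named here, the only anchor is compound 1 at 10000 nM, and the direction of any shift is unknown.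

No shift beyond the scatter is therefore expected, and the estimated step is a 1.3-fold lower number from compound 1 to compound 4 (0.10 log units; within the scatter). Going by these compounds, the range is kept wide since this change is untested.

Compound 4 is estimated at 8000 nM, with an expected range of 2500 nM to 20000 nM.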

Compound 4, half-maximal inhibitory concentration: 750 nM
For compound 4 the middle estimate is 11-fold (1.03 log units) above the measured one; the whole stated range lies above it.
By their numbers in this assay, from the lowest: compound 4; then compounds 3, 1 and 2 (each within the scatter of the next).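

In this assay, the attachment of the indole on the nitrogen on an aromatic ring is the only place in this series where a step lies beyond the scatter: 1H-indol-4-yl in place of 1H-indol-6-yl gives a 13-fold lower number from compound 1 to compound 4 (1.12 log units; beyond the scatter). The two groups have the same atoms and the same counts of rings and hydrogen-bond donors, so the pair is separated by the attachment point alone, whereas the fluoro changes on the aromatic group on the sulfonyl sulfur give only no change at the digits printed from compound 1 to compound 2 (within the scatter) and a 2.0-fold lower number from compound 1 to compound 3 (0.30 log units; within the scatter). Nothing available explains this shift or ties it to any property of either group.

Going by these compounds, only two attachment points of the indole appear here, so the standing of 1H-indol-5-yl and 1H-indol-7-yl on the same nitrogen remains open, as does the effect of a substituent such as a carboxylic acid or a dimethylamino group on the 1H-indol-4-yl ring. On these data alone, it is also open whether the fluoro changes stay within the scatter with 1H-indol-4-yl in place, for example with 2,4-difluorophenyl or phenyl on the sulfonyl sulfur.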